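The source may hold more compounds than are shown below. What is called first, only, known or untested is meant among the compounds shown, and "the series" means these compounds.

Working notes on the series. Within the data shown here, compound 2 `Nc1ccccc1NC(=O)CCCNCC(=O)Nc1cccc([N+](=O)[O-])c1` in a functional assay on the whole organism (Ehrlich cells, Mus musculus) for antiproliferative activity, with a stated time of 24 h, at a dose of 0.2 mmol/kg by the intraperitoneal route (on this read-out higher numbers stand for more inhibition at the one dose given (going by the name of the read-out) and lower numbers for less inhibition), gives 36%, the higher of the two numbers so far; compound 1 `Nc1ccccc1NC(=O)CCCNCC(=O)Nc1cccc(Cl)c1` gives 22.5% in this assay. Among the measured compounds shown here, the only measured step is a number 13.5 percentage points higher from compound 1 to compound 2 (beyond the scatter), which ties the higher number to the nitro group. Compound 3 `Nc1ccccc1NC(=O)CCCNCC(=O)Nc1cc(Cl)ccc1Cl` has not been measured in this assay; it differs from compound 2 by 2,5-dichlorophenyl in place of 3-nitrophenyl on an amide-type nitrogen. For the measured compounds named here, the change removes the nitro group and brings back chlorine, so the measured step read in reverse is the relevant guide: a fall of roughly the size seen in a number 13.5 percentage points higher from compound 1 to compound 2 (beyond the scatter) is expected, with the second chlorine of compound 3 having no precedent among the measured compounds, which widens the range. Compound 3 is therefore expected to give 24% in this assay, within 10% to 40%. The expected step is a number 12 percentage points lower from compound 2 to compound 3 (beyond the scatter).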

Compound 3, a percentage reported as inhibition, in the whole organism at one dose (the size of the read-out at that dose, not a potency): 50.9%
Compound 3: middle estimate off by 26.9 percentage points, on the low side; the measured number lies above the stated range.
By their numbers in this assay, from the lowest: compound 1; then compound 2; then compound 3.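

In this assay the aryl group on the amide-type nitrogen is not ranked by nitro against chlorine alone: the step of a number 14.9 percentage points higher from compound 2 to compound 3 (beyond the scatter) comes with 2,5-dichlorophenyl in place of 3-nitrophenyl, so a ring carrying only chlorine can stand above the nitro compound. The step of a number 28.4 percentage points higher from compound 1 to compound 3 (beyond the scatter) comes with chloro in place of hydrogen on an aromatic carbon, which shows that this ring still responds to a second substituent on top of the first chlorine. No available measurement bears on why the second chlorine goes with the higher number.

The compounds shown leave open whether this rise is particular to chlorine or whether a bromo, methyl or methoxy group in its place would go with a similar number. Also open, going by these compounds, is whether the order of the three compounds holds at other doses.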